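Replacing bromine with a selenium-bearing group

The compounds below may be only part of what the source reports. "The series", "measured", "known", "first", "only" and "open" are said of these compounds alone.

In a functional assay on A549 cells (Homo sapiens) for antiproliferative activity, read by MTT assay, with a stated time of 48 h (on this read-out lower numbers stand for stronger inhibition and higher numbers for weaker inhibition), compound 1 `COc1ccc(N(C)c2ccnc(Cl)n2)cc1[N+](=O)[O-]` gives 3780 nM, and compound 2 `COc1ccc(N(C)c2ccnc(Cl)n2)cc1OCCCCBr` gives 591 nM, the lower of the two numbers. The next structure is compound 3 `COc1ccc(N(C)c2ccnc(Cl)n2)cc1OCCCCC[Se]C#N`, and its change is a group of 4 heavy atoms (2 carbon, 1 nitrogen, 1 selenium; no ring) in place of one bromine atom, on a saturated chain carbon, four bonds along the chain from an oxygen on an aromatic ring. Within the data shown here, only one measured step bears on this: putting 4-bromobutoxy in place of nitro on an aromatic carbon gave a 6.4-fold lower number from compound 1 to compound 2 (0.81 log units; beyond the scatter), a modest step beyond the scatter. That step introduced the chain but did not alter the bromine, so it offers only indirect guidance. Among the measured compounds shown here, no measured compound contains selenium, and the size of the next step is therefore uncertain. A modest further drop in this assay is a cautious expectation, and the estimated step is a 3.0-fold lower number from compound 2 to compound 3 (0.47 log units; beyond the scatter). For compound 3, the estimated value is 200 nM, with an expected range from 40 nM to 900 nM.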

Compound 3, half-maximal inhibitory concentration: > 10000 nM
Compound 3 was reported as a limit (the forecaster's own chance of this, stated with the estimate: 1%); middle value at least 50-fold (1.69 log units) from the limit.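

The change on this saturated chain carbon, four bonds along the chain from an oxygen on an aromatic ring, gave an at least 16-fold higher number from compound 2 to compound 3 (1.22 log units; beyond the scatter). This runs opposite to the earlier drop that came with the 4-bromobutoxy chain, so what sits at the end of the chain strongly affects the read-out, and the chain alone does not secure activity. Compound 3 is reported in this assay only as a limit, > 10000 nM, which makes the size of this step a minimum and not an exact measurement: the limit of > 10000 nM in this assay, at which 1 of the 3 values shown sits.

The compounds shown do not separate the selenium from the nitrile, as both enter together. From the compounds shown here alone, it also stays open whether an amine or a hydroxyl group at the end of the chain would keep the activity of compound 2.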